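A few compounds are considered here, and "the series" means these few. Any claim that something is new, unique, unknown or untested is made for them only; others in the source may bear on it.

Of the compounds shown here, two from this series have been tested in an assay on CHO cells for displacement of a labelled ligand from adenosine receptor A1 (Homo sapiens); a lower number here means a stronger inhibitor, a higher number a weaker inhibitor. Compound 1 `c1coc(-c2nc3nc(NC4CCCCC4)nc(NC4CCCCC4)n3n2)c1` carries two cyclohexylamino groups on the shared core and in this assay gives 306 nM. Compound 2 `CNc1nc(NCc2ccc(F)cc2)n2nc(-c3ccco3)nc2n1` carries a methylamino group and a fluorobenzylamino group instead, and in this assay compound 2 gives 3080 nM. Of the two numbers, that of compound 2 is the higher, and the gap to compound 1 lies well beyond the usual scatter, so compound 2 is the weaker of the two measured inhibitors.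

Compound 3 `Fc1ccc(CNc2nc(NC3CCCCC3)nc3nc(-c4ccco4)nn23)cc1` has not yet been measured. It differs from compound 2 in one place: cyclohexyl in place of methyl on a nitrogen on an aromatic ring. The fluorobenzylamino group is kept, so compound 3 sits between compound 2 and compound 1 in its substitution pattern.

Compound 1, with its two cyclohexylamino groups, is the stronger of the measured pair, and compound 3 takes one of them on. On that basis the step from compound 2 to compound 3 is expected to be a drop in the number by a 4.7-fold lower number from compound 2 to compound 3 (0.68 log units; beyond the scatter), beyond the scatter. For compound 3 a value of about 650 nM is expected in this assay, plausibly falling anywhere from 200 nM to 2000 nM.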

Compound 3, inhibition constant: > 100000 nM
Compound 3: only a limit was reported; the forecaster's own chance of this, stated with the estimate: 2%; middle value at least 150-fold (2.18 log units) away from the limit.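

In this assay, compound 3 gives only a limit, > 100000 nM, not a number: the limit of > 100000 nM in this assay, at which 1 of the 3 values shown sits.

Even so, the result shows that with the fluorobenzylamino group kept, this nitrogen on an aromatic ring does not accept the change from methylamino to cyclohexylamino without a large loss, giving an at least 32-fold higher number from compound 2 to compound 3 (1.51 log units; beyond the scatter). The other step shows that a cyclohexylamino group does not bring the stronger binding of compound 1 with it whatever stands on the second nitrogen, since 4-fluorobenzyl in place of one cyclohexyl gives an at least 320-fold higher number from compound 1 to compound 3 (2.51 log units; beyond the scatter), so the two amino groups cannot be read as acting independently of each other.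

The compounds shown leave open how the number moves for groups on this nitrogen other than methyl and cyclohexyl, such as ethyl, isopropyl or cyclopropyl, and so where the loss sets in. They also leave open whether an unsubstituted amino group at this place would give a lower or a higher number than the methylamino group of compound 2, and how far the true value of compound 3 lies beyond its limit.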